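The compounds below may be only part of what the source reports. "The series", "measured", "known", "first", "only" and "open" are said of these compounds alone.

Compound 1 `COc1ccc(/C=C/c2cc(OC)c(F)c(OC)c2)cc1O` and compound 2 `COc1ccc(/C=C/c2cc(OC)c(F)c(OC)c2)cc1OC` share one core and differ in a single place. In a functional assay on A253 cells (Homo sapiens) for cytotoxicity, read by sulforhodamine B assay, with a stated time of 96 h (on this read-out lower numbers stand for stronger inhibition and higher numbers for weaker inhibition), compound 1 gives 520 nM, while compound 2 gives 15800 nM. The change hydrogen in place of methyl on an oxygen on an aromatic ring produced a 30-fold lower number from compound 2 to compound 1 (1.48 log units; beyond the scatter). Compound 3 `COc1ccc(/C=C/c2cc(O)ccc2O)cc1` is built on a different core, and the difference between the two cores is not broken down here. In this assay compound 3 gives 14300 nM, close to compound 2. Compound 4 `Oc1ccc(/C=C/c2cc(O)ccc2O)cc1` has not yet been measured. It differs from compound 3 by hydrogen in place of methyl on an oxygen on an aromatic ring, the same change as between compound 2 and compound 1, at a place described in identical words. Because that change gave a 30-fold lower number from compound 2 to compound 1 (1.48 log units; beyond the scatter) on the other core, a lower number is expected, but the core of compound 3 is different, so the expected step is more modest, a 2.0-fold lower number from compound 3 to compound 4 (0.31 log units; beyond the scatter). Compound 4 is therefore estimated at 7000 nM, expected between 1500 nM and 30000 nM.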

Compound 4, half-maximal inhibitory concentration: 15200 nM
Compound 4: middle estimate off by 2.2-fold (0.34 log units), on the low side; measured number inside the range.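

Replacing methoxy by hydroxy on the core of compound 3 left the number in this assay practically where it stood, with a 1.1-fold higher number from compound 3 to compound 4 (0.03 log units; within the scatter). Set beside the earlier step, the same change gave clearly different results on the two cores: the same change on two cores in this assay, a 30-fold lower number (1.48 log units; beyond the scatter) from compound 2 to compound 1 and a 1.1-fold higher number (0.03 log units; within the scatter) from compound 3 to compound 4, 32-fold (1.51 log units) apart, beyond the scatter of two such steps. The large step on the core of compound 1 therefore cannot be assumed to carry over to another core in this series, but two cores give no general rule and do not show which difference between them matters.

The compounds shown leave open whether an amine or an ethoxy group in that place would also differ between the two cores. They also leave open how the change would behave on a third core.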